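One Methoxy Fewer: From Compound 2 to Compound 3

The source may report more compounds than this note shows. Statements on the series, on what has been measured and on what is new or still open speak of the compounds shown alone.

compound 1 `COc1ccc(-c2cc(/C=C/C(=O)c3ccc(N)cc3)[nH]n2)cc1`: 98%
compound 2 `COc1cc(-c2cc(/C=C/C(=O)c3ccc(N)cc3)[nH]n2)cc(OC)c1OC`: 91%

Of the compounds shown here, two have been measured in a functional assay on CCRF-CEM cells (Homo sapiens) for cytotoxicity, read by sulforhodamine B assay, with a stated time of 48 h, tested at 0.1 uM; a lower number here means a stronger effect, a higher number a weaker effect of the compound at the concentration tested. Compound 1 gives 98% in it, and compound 2 gives 91%. Compound 2 stands lowest of the two numbers, yet its nearest neighbour, compound 1, lies only a little higher, within the usual scatter, so no order between the two can be read from these figures.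

Compound 3 `COc1ccc(-c2cc(/C=C/C(=O)c3ccc(N)cc3)[nH]n2)cc1OC` is not yet measured. It differs from compound 2 in one place: hydrogen in place of methoxy on an aromatic carbon. The position is ortho to a methoxy group and meta to a large group.

Since compound 1 and compound 2 sit so close to each other, the step from one methoxy count to another is expected to yield a number 3 percentage points higher from compound 2 to compound 3 (within the scatter), no change beyond the scatter. Compound 3 is therefore estimated at 94%, in a range from 82% to 104%.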

Compound 3, a percentage reported as activity, at one concentration (the size of the read-out at that concentration, not a potency): 97%
For compound 3 the middle estimate is 3 percentage points below the measured one, within the range that was stated.
By their numbers in this assay, from the lowest: compounds 2, 3 and 1 (each within the scatter of the next).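

In this assay, among these compounds, the single change of hydrogen in place of methoxy gives a number 6 percentage points higher from compound 2 to compound 3 (within the scatter) on that aromatic carbon, ortho to a methoxy group and meta to a large group. The reverse kind of change, methoxy in place of hydrogen on an aromatic carbon, gives a number 1 percentage points lower from compound 1 to compound 3 (within the scatter) and likewise leaves the number within the scatter, so at this one concentration neither single step separates the compounds, which the earlier pair, differing in more than one place, could not show. Nothing available here bears on why these numbers stay together.

Going by these compounds, whether a hydroxyl group, a fluorine atom or an ethoxy group on this aromatic carbon would move the number beyond the scatter remains open. The same holds for how these three compounds would compare at other concentrations.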